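Compound 4: triazole arm in place of the thiocarbonyl chain

The source may hold more compounds than are shown below. What is called first, only, known or untested is meant among the compounds shown, and "the series" means these compounds.

In a toxicity assay on HeLa cells (Homo sapiens) for cytotoxicity, read by MTT assay, with a stated time of 24 h (on this read-out higher numbers stand for weaker inhibition and lower numbers for stronger inhibition), compound 1 `Cc1ncc([N+](=O)[O-])n1CC(O)CSC(=S)N1CCC(C)CC1` gives 1820000 nM and compound 3 `CCN(C)C(=S)SCC(O)Cn1c([N+](=O)[O-])cnc1C` gives 4150000 nM. Compound 2 `Cc1ncc([N+](=O)[O-])n1CC(O)CSC(=S)N(C)C` gives in this assay only a limit, > 5000000 nM, and so stands at the limit of > 5000000 nM in this assay, at which 1 of the 3 values shown sits. The measured steps, an at least 2.7-fold higher number from compound 1 to compound 2 (0.43 log units; beyond the scatter) and a 2.3-fold higher number from compound 1 to compound 3 (0.36 log units; beyond the scatter), vary only the amine on the thiocarbonyl carbon, while an at least 1.2-fold lower number from compound 2 to compound 3 (0.08 log units; that floor lies within the scatter) is a floor within the scatter. Compound 4 `Cc1ncc([N+](=O)[O-])n1CC(O)Cn1nccn1` differs from compound 2 by a group of 5 heavy atoms (2 carbon, 3 nitrogen; one five-membered aromatic ring with 3 hetero atoms) in place of a group of 6 heavy atoms (3 carbon, 1 nitrogen, 2 sulfur; no ring), on a saturated chain carbon, two bonds along the chain from an oxygen on a saturated carbon. Within the data shown here, no measured step touches this change, so the series gives no direction for it; all three measured values sit at the weak end of this assay. Compound 4 is expected near 5000000 nM, within 1500000 nM to 10000000 nM, an estimated a number no higher from compound 2 to compound 4 (the limit leaves the size open) from a starting point that is itself a limit.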

Compound 4, half-maximal inhibitory concentration: > 5000000 nM
Compound 4: a limit, no number (the forecaster's own chance of this, stated with the estimate: 55%); the middle value sits exactly at the limit.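

In this assay compound 4 gives only a limit, > 5000000 nM. Among these compounds, compound 2 also gives only a limit, > 5000000 nM, so no step between compound 2 and compound 4 can be read. Going by these compounds, whether the 2H-1,2,3-triazol-2-yl arm shifts the value at all stays open.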